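The compounds below may be only part of what the source reports. "The series", "measured", "known", "first", "only" and "open" are said of these compounds alone.

Compound 3 `N#CC1=C(N)Oc2ccc(Br)cc2C1CC(=O)c1ccc(Br)cc1` gives 43.6% in an ADME assay on MCF-10A cells (Homo sapiens) for cytotoxicity, read by sulforhodamine B assay, with a stated time of 72 h, tested at 30 uM; on this read-out higher numbers stand for a stronger effect at the one concentration tested and lower numbers for a weaker effect. Among the three measured compounds its number is the lowest shown, though it lies within the scatter of compound 1 `COc1cccc(C(=O)CC2C(C#N)=C(N)Oc3ccc(Br)cc32)c1`, which gives 43.7%, and of compound 2 `Cc1ccc(C(=O)CC2C(C#N)=C(N)Oc3ccc(Cl)cc32)cc1`, which gives 53.3%. Compound 4 `Cc1ccc(C(=O)CC2C(C#N)=C(N)Oc3ccc(Br)cc32)cc1` carries methyl in place of bromo on an aromatic carbon. Going by the values given here, the one measured step that touches the same carbonyl-bound ring, 4-bromophenyl in place of 3-methoxyphenyl, is a number 0.1 percentage points lower from compound 1 to compound 3 (within the scatter), within the scatter. Among the compounds with values here, compound 2 and compound 4 share the 4-methylphenyl but differ elsewhere, so their values give no step. Compound 4 is therefore expected to differ from compound 3 by a number 3.4 percentage points higher from compound 3 to compound 4 (within the scatter), a step within the scatter. The estimate for compound 4 in this assay is 47%, between 35% and 60%.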

Compound 4, a percentage reported as activity, at one concentration (the size of the read-out at that concentration, not a potency): 33.5%
The estimate for compound 4 lay 13.5 percentage points above the measured number, outside the stated range (below it).
By their numbers in this assay, from the lowest: compound 4; then compounds 3, 1 and 2 (each within the scatter of the next).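

In this assay, going by these compounds alone, the carbonyl-bound ring shows a change beyond the scatter for the first time: methyl in place of bromo gives a number 10.1 percentage points lower from compound 3 to compound 4 (beyond the scatter) and 4-methylphenyl in place of 3-methoxyphenyl gives a number 10.2 percentage points lower from compound 1 to compound 4 (beyond the scatter) on the same ring. The halogen on the other ring also matters here, as bromo in place of chloro gives a number 19.8 percentage points lower from compound 2 to compound 4 (beyond the scatter) with the 4-methylphenyl kept. Compound 4 therefore stands lowest of the four. As far as these compounds go, whether an amine or a carboxylic acid on the carbonyl-bound ring would lower the number further or raise it stays open. Nothing available here explains these steps.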